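This account rests on a few compounds, and the source may have more. Where it says the series, first, only, none or still open, it means among the compounds named here.

Measured so far:
- compound 1, `C#CCN(Cc1ccc2nc(C)nc(O)c2c1)c1ccc(C(=O)N[C@@H](CCC(=O)O)C(=O)N[C@@H](CCC(=O)O)C(=O)O)cc1`: 160 nM
- compound 2, `C#CCN(Cc1ccc2nc(C)nc(O)c2c1)c1ccc(C(=O)N[C@@H](CC(C)C(=O)O)C(=O)N[C@@H](CCC(=O)O)C(=O)O)cc1`: 410 nM
- compound 3, `C#CCN(Cc1cc2c(O)nc(C)nc2cc1C)c1ccc(C(=O)N[C@@H](CCC(=O)O)C(=O)N(CC)[C@@H](CCC(=O)O)C(=O)O)c(F)c1`: 70 nM

These three compounds were tested in a functional assay (L1210 cells) for inhibition, with Mus musculus as the target; on this read-out lower numbers stand for stronger inhibition and higher numbers for weaker inhibition. Among the three numbers, compound 1 stands second highest: compound 3 sits at a lower number, and compound 2 at a higher one, both gaps beyond the scatter. Compound 4, `C#CCN(Cc1ccc2nc(C)nc(O)c2c1)c1ccc(C(=O)N[C@@H](CCC(=O)O)C(=O)N(C)CC(=O)O)cc1`, has not yet been measured. It differs from compound 1 in one place: (carboxymethyl)(methyl)amino in place of (1,3-dicarboxypropyl)amino on a carbonyl carbon. For the measured compounds named here, only one measured step alters the same chain region: a 2.6-fold higher number from compound 1 to compound 2 (0.41 log units; beyond the scatter), where a single methyl on a chain carbon already pushed the number up. Compound 3 carries an ethyl on an amide nitrogen but differs in several other places too, so its value can only be noted, not read as a step. The change to compound 4 is larger than the change to compound 2, removing a stereocentre and two of the three hydrogen-bond donors. A higher number is therefore expected for compound 4, with a 5.0-fold higher number from compound 1 to compound 4 (0.70 log units; beyond the scatter), giving an estimated 800 nM in this assay, within a range of 250 nM to 3000 nM.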

Compound 4, half-maximal inhibitory concentration: 1100 nM
The estimate for compound 4 lay 1.4-fold (0.14 log units) below the measured number; measured number inside the range.
By their numbers in this assay, from the lowest: compound 3; then compound 1; then compound 2; then compound 4.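

In this assay, replacing (1,3-dicarboxypropyl)amino with (carboxymethyl)(methyl)amino on this carbonyl carbon gives a 6.9-fold higher number from compound 1 to compound 4 (0.84 log units; beyond the scatter), so the group held at this position clearly affects the read-out. The change bundles several differences: the entering group has fewer heavy atoms, 1 hydrogen-bond donor against 3, and no defined stereocentre against 1, so this single step cannot show which difference matters. Nothing measured here explains the weaker inhibition.

The compounds shown leave open how much of the step belongs to the methyl and how much to the smaller chain, which a plain (carboxymethyl)amino group would help to separate. They also leave open whether a primary amide could stand in place of the carboxylic acid in the entering group.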